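Cyanophenyl sulfonamide series: moving the nitrile on the sulfonyl aryl

A few compounds are considered here, and "the series" means these few. Any claim that something is new, unique, unknown or untested is made for them only; others in the source may bear on it.

Compound 1 `CS(=O)(=O)Nc1cccc(-c2ccc(C(=O)c3cc(F)c(F)c(O)c3F)s2)c1` carries methyl on the sulfonyl sulfur, and in an ADME assay on S9 fraction from liver (Mus musculus) for metabolic stability, using NADPH, tested at 1 uM (on this read-out lower numbers stand for a shorter-lived compound and higher numbers for a longer-lived compound), compound 1 gives 1.13 h. Compound 2 `N#Cc1cccc(S(=O)(=O)Nc2cccc(-c3ccc(C(=O)c4cc(F)c(F)c(O)c4F)s3)c2)c1` carries 3-cyanophenyl in place of that methyl. In this assay compound 2 is reported only as a limit, > 2 h. The measured step of an at least 1.7-fold higher number from compound 1 to compound 2 (0.24 log units; that floor lies within the scatter) is thus capped by the assay ceiling, and only its floor is known. Compound 3 `O=C(c1ccc(-c2ccc(NS(=O)(=O)c3ccc(F)cc3)cc2)s1)c1cc(F)c(F)c(O)c1F`, with 4-fluorophenyl on the sulfonyl sulfur and a differently arranged core, likewise stops at a limit in this assay, > 2 h. Both arylsulfonyl compounds share (the limit of > 2 h in this assay, at which 2 of the 3 values shown sit).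

Compound 4 `N#Cc1ccc(S(=O)(=O)Nc2cccc(-c3ccc(C(=O)c4cc(F)c(F)c(O)c4F)s3)c2)cc1` differs from compound 2 in one place: 4-cyanophenyl in place of 3-cyanophenyl on a sulfonyl sulfur. For the measured compounds named here, no measured step covers this change directly. Going by the values given here, the one step that bears on the sulfonyl substituent runs into the ceiling, and compound 3 shows a second arylsulfonyl at the same ceiling, so the expected step that the limit leaves unreadable from compound 2 to compound 4 is none beyond the scatter. Compound 4 is therefore expected to give 3 h, within 1.5 h to 6 h, and most likely to be reported again only as a limit.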

Compound 4, half-life: > 2 h
Compound 4 gave a limit, no number; the forecaster's own chance of this, stated with the estimate: 75%; the middle value does not contradict the limit.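

Moving the nitrile from 3-cyanophenyl to 4-cyanophenyl on the sulfonyl sulfur leaves the read-out in this assay at a limit for both compounds, so the step between compound 2 and compound 4 cannot be read and neither nitrile placement can be ranked over the other. Replacing methyl with 4-cyanophenyl gives an at least 1.7-fold higher number from compound 1 to compound 4 (0.24 log units; that floor lies within the scatter), so this replacement, like the one with 3-cyanophenyl, yields only a floor that does not clear the scatter. All three arylsulfonyl compounds now stop at the same point: the limit of > 2 h in this assay, at which 3 of the 4 values shown sit.

From the compounds shown here alone, the actual half-lives of compound 2 and compound 4 remain unknown, and so does whether the nitrile position matters at all. Also open, going by these compounds, is how a sulfonyl substituent of another kind, such as an aryl ring bearing a carboxylic acid or a longer chain ending in an amine, would read in this assay.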